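Swapping the ring nitrogen substituent: from cyclohexyl to nitrophenyl

This account rests on a few compounds, and the source may have more. Where it says the series, first, only, none or still open, it means among the compounds named here.

The two measured compounds share one core and differ only in the group on an amide-type nitrogen in a ring. Compound 1 `CC(C)N1C(=O)NC2(CC2c2ccc3cccc(OCc4ccccc4)c3n2)C1=O` carries isopropyl there and gives 100 mg/kg in a functional assay on the whole organism (strain Kunming) with Mus musculus as the target, in the maximal electroshock model, with a stated time of 4 h; a lower number here means that less compound is needed, a higher number that more compound is needed for the effect. Compound 2 `O=C1NC2(CC2c2ccc3cccc(OCc4ccccc4)c3n2)C(=O)N1C1CCCCC1` carries cyclohexyl and gives 300 mg/kg in this assay, the highest of the two numbers; the step of a 3.0-fold higher number from compound 1 to compound 2 (0.48 log units; beyond the scatter) separates them. Compound 3 `O=C1NC2(CC2c2ccc3cccc(OCc4ccccc4)c3n2)C(=O)N1c1ccc([N+](=O)[O-])cc1` is not yet measured; it differs from compound 2 by 4-nitrophenyl in place of cyclohexyl on an amide-type nitrogen in a ring. For the measured compounds named here, only the step from compound 1 to compound 2 bears on this change, and it touched the same nitrogen, so the one precedent is modest and points upward for a bulkier group. Going by the values given here, no measured compound carries an aromatic group at this nitrogen, so the direction is uncertain, and the expected step of no change at the digits printed from compound 2 to compound 3 (within the scatter) is none beyond the scatter. Compound 3 is therefore estimated at 300 mg/kg, within a range from 100 mg/kg to 1000 mg/kg.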

Compound 3, minimum effective dose: 300 mg/kg
For compound 3 middle estimate and measured number coincide at the digits printed; measured number inside the range.
By their numbers in this assay, from the lowest: compound 1; then compounds 2 and 3 (each within the scatter of the next).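

Replacing the saturated cyclohexyl with the aromatic 4-nitrophenyl gives no change at the digits printed from compound 2 to compound 3 (within the scatter) in this assay, so at this nitrogen, an aromatic ring bearing hydrogen-bond acceptors reads the same as a carbon-only saturated ring. Measured from the isopropyl compound, the new group gives a 3.0-fold higher number from compound 1 to compound 3 (0.48 log units; beyond the scatter), matching a 3.0-fold higher number from compound 1 to compound 2 (0.48 log units; beyond the scatter), so both six-membered rings stand on the same side of compound 1. No measurement is available to explain this result.

The compounds shown cannot separate the aromatic ring from its nitro group, which plain phenyl or 4-aminophenyl at this nitrogen would help to do. They also leave open how a methyl group, or simply the hydrogen on this nitrogen, would compare with the isopropyl of compound 1.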